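Pyrimidine for carbamate on the piperidine: two cores compared

The source may hold more compounds than are shown below. What is called first, only, known or untested is meant among the compounds shown, and "the series" means these compounds.

The series is followed in a functional assay on cells for agonist activity at Glucose-dependent insulinotropic receptor (Homo sapiens), read by a luciferase reporter, with a stated time of 6 h; on this read-out lower numbers stand for an effect already at smaller amounts and higher numbers for an effect only at larger amounts of compound. Compound 1 `CON(C)C(=O)c1ccc(-c2csc3c(OC4CCN(C(=O)OC(C)(C)C)CC4)ncnc23)cc1` gives 64 nM and its partner compound 2 `CCc1cnc(N2CCC(Oc3ncnc4c(-c5ccc(C(=O)N(C)OC)cc5)csc34)CC2)nc1` gives 199 nM. The structural change between them is 5-ethylpyrimidin-2-yl in place of tert-butoxycarbonyl on an amine nitrogen in a ring; the step it made was a 3.1-fold higher number from compound 1 to compound 2 (0.49 log units; beyond the scatter).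

Compound 3 `CON(C)C(=O)c1ccc(-c2ccc(OCC3CCN(C(=O)OC(C)(C)C)CC3)cn2)cc1` carries a different core, and the difference between its core and that of compound 1 is not broken down here. In this assay compound 3 gives 171 nM. Against compound 2 its number is within the scatter; against compound 1 it is beyond the scatter, as noted with the value pair. Compound 4 `CCc1cnc(N2CCC(COc3ccc(-c4ccc(C(=O)N(C)OC)cc4)nc3)CC2)nc1` is the still unmeasured partner of compound 3, and the change from compound 3 to compound 4 is 5-ethylpyrimidin-2-yl in place of tert-butoxycarbonyl on an amine nitrogen in a ring. The two "place" descriptions agree word for word, so this is the same change as that from compound 1 to compound 2, now made on the other core.

For compound 4 the expectation in this assay rests on compound 1 and compound 2, where the step was a 3.1-fold higher number from compound 1 to compound 2 (0.49 log units; beyond the scatter); carried over to compound 3, an estimated step of a 2.9-fold higher number from compound 3 to compound 4 (0.47 log units; beyond the scatter) is expected. Whether a change transfers across cores is not shown by any pair here, so the estimate is kept wide. Compound 4 is therefore expected to give about 500 nM, between 200 nM and 1300 nM.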

Compound 4, half-maximal effective concentration: 319 nM
Compound 4: the middle estimate sits 1.6-fold (0.20 log units) above what was measured; measured number inside the range.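

In this assay, 5-ethylpyrimidin-2-yl in place of tert-butoxycarbonyl on the amine nitrogen in the ring gives a 1.9-fold higher number from compound 3 to compound 4 (0.27 log units; within the scatter), whereas the same change on the core of compound 1 gave a step beyond the scatter. Among these compounds, the two steps point the same way and cannot be told apart, so on these two cores the change carries over as far as the data can resolve: the same change on two cores in this assay, a 3.1-fold higher number (0.49 log units; beyond the scatter) from compound 1 to compound 2 and a 1.9-fold higher number (0.27 log units; within the scatter) from compound 3 to compound 4, 1.7-fold (0.22 log units) apart, within the scatter of two such steps This is still only one change compared on two cores, so it does not show that the step would hold on any further core or for any other group on that nitrogen, and the step on the second core, taken alone, does not establish a real difference between compound 3 and compound 4.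

Still open, going by these compounds, is how other groups on the same nitrogen would behave, for instance a longer chain in place of the ethyl of 5-ethylpyrimidin-2-yl, or a plain acetyl in place of either group. The compounds shown also leave the far end of the molecule untouched, so a carboxylic acid in place of the methoxy-methyl amide remains a separate question on both cores.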